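Notes on the ester analogue of compound 3

The source may report more compounds than this note shows. Statements on the series, on what has been measured and on what is new or still open speak of the compounds shown alone.

Compound 3 `N#Cc1cc(Cl)c(Nc2nc3c(Nc4ccc(C(F)(F)F)cc4)ncnc3s2)c(Cl)c1` holds the highest number of the three measured in a functional assay on HEK293 cells for antagonist activity at transient receptor potential cation channel subfamily V member 1 (Rattus norvegicus), read by calcium flux; on this read-out lower numbers stand for stronger inhibition and higher numbers for weaker inhibition; compound 3 gives 53 nM. Its nearest neighbour on the numbers is compound 2 `Cc1cccc(C)c1Nc1nc2c(Nc3ccc(C(F)(F)F)cc3)ncnc2s1`, which gives 6 nM, and the step of an 8.8-fold higher number from compound 2 to compound 3 (0.95 log units; beyond the scatter) lies beyond the scatter. Compound 1 `FC(F)(F)c1ccc(Nc2ncnc3sc(Nc4c(Cl)cccc4Cl)nc23)cc1` gives 3 nM, and the step of an 18-fold higher number from compound 1 to compound 3 (1.25 log units; beyond the scatter) also lies beyond the scatter, whereas a 2.0-fold higher number from compound 1 to compound 2 (0.30 log units; within the scatter) lies within it. Compound 4 `COC(=O)c1cc(Cl)c(Nc2nc3c(Nc4ccc(C(F)(F)F)cc4)ncnc3s2)c(Cl)c1` carries methoxycarbonyl in place of cyano on an aromatic carbon. Within the data shown here, the only measured step at this aromatic carbon is an 18-fold higher number from compound 1 to compound 3 (1.25 log units; beyond the scatter), in which cyano in place of hydrogen raised the number; no measured step exchanges one substituent for another at this carbon, so there is no direct precedent for the present change. The expectation is that a substituent at this carbon keeps the number near that of compound 3 rather than returning it toward compound 1, so the step of a 1.1-fold higher number from compound 3 to compound 4 (0.05 log units; within the scatter) is expected to stay within the scatter. Compound 4 is estimated at 60 nM, with a range from 20 nM to 200 nM.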

Compound 4, half-maximal inhibitory concentration: 3190 nM
Compound 4: the middle estimate sits 53-fold (1.73 log units) below what was measured, and the stated range ends below it.
By their numbers in this assay, from the lowest: compounds 1 and 2 (each within the scatter of the next); then compound 3; then compound 4.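

In this assay the aromatic carbon para to a large group responds strongly to which substituent it carries, not only to whether it carries one. Methoxycarbonyl in place of cyano gives a 60-fold higher number from compound 3 to compound 4 (1.78 log units; beyond the scatter) and so is no neutral swap at this carbon, while methoxycarbonyl in place of hydrogen gives a 1100-fold higher number from compound 1 to compound 4 (3.03 log units; beyond the scatter) and extends the rise already seen with cyano. No measurement at hand bears on why the number moves this far.

Only hydrogen, cyano and methoxycarbonyl are shown at this carbon, so it remains open whether the rise follows the count of heavy atoms that enter or belongs to the ester itself. A carboxylic acid, a primary amide or a methyl group here could fall near compound 3 or near compound 4, and the compounds shown do not tell which.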